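This account rests on a few compounds, and the source may have more. Where it says the series, first, only, none or still open, it means among the compounds named here.

In a functional assay on K562 cells (Homo sapiens) for antiproliferative activity, read by MTT assay, with a stated time of 72 h (a lower number here means a stronger inhibitor, a higher number a weaker inhibitor), compound 1 (`O=C1C[C@@H]2O[C@@H](Cc3ccccc3)[C@@H](O)[C@@H]2O1`) stands at 20 nM and compound 2 (`O=C1C[C@H]2O[C@H](Cc3ccccc3)[C@H](OCc3ccccc3)[C@H]2O1`) stands at 140 nM as the higher of the two numbers, a gap beyond the usual scatter. Compound 3 (`O=C1C[C@H]2O[C@H](Cc3ccccc3)[C@H](O)[C@H]2O1`) has not yet been measured. The change from compound 2 to compound 3 is hydrogen in place of benzyl on an oxygen on a saturated carbon in one place: hydrogen in place of benzyl on an oxygen on a saturated carbon, or benzyloxy to hydroxy. Going by the values given here, no measured pair shows this change on its own, so its size in this assay is not known from the data. A moderate step toward a lower number is expected, though it may not clear the scatter by much. Among the compounds with values here, the only guide is compound 1, which also carries a hydroxy group and gives 20 nM against the higher number of compound 2. For compound 3 the estimated value is 70 nM with 15 nM to 300 nM as the expected range. The step expected by this estimate is a 2.0-fold lower number from compound 2 to compound 3 (0.30 log units; within the scatter) in all.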

Compound 3, half-maximal inhibitory concentration: 510 nM
Beside the measured number, compound 3's estimate is 7.3-fold (0.86 log units) below it; the whole stated range lies below it.
By their numbers in this assay, from the lowest: compound 1; then compound 2; then compound 3.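

In this assay, taking the benzyl off the oxygen on a saturated carbon did not lower the number but raised it, a 3.6-fold higher number from compound 2 to compound 3 (0.56 log units; beyond the scatter), so in this configuration the benzyloxy form is the better of the two and the hydroxy group does not by itself bring a low number. The second step is larger, a 26-fold higher number from compound 1 to compound 3 (1.41 log units; beyond the scatter), and it shows that the low number of compound 1 depends on how its atoms are arranged in space, which the earlier pair of compounds could not separate from the change of group. This large step has a single source: the fact that compounds 1 and 3 differ only in the configuration as drawn.

The compounds shown leave open how a benzyl on that oxygen would act in the configuration of compound 1, as the benzyloxy and hydroxy forms can be compared only in the configuration of compound 3. They also leave open whether a shorter group such as methyl or a longer chain such as phenylethyl on that oxygen, or an amine in place of the oxygen, would give a lower or a higher number in either configuration.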